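The source may report more compounds than this note shows. Statements on the series, on what has been measured and on what is new or still open speak of the compounds shown alone.

Measured so far:
Compound 1 `CC1(c2ccc(F)cc2)NC(=O)N(CC(O)CN2CCN(c3ccccc3Cl)CC2)C1=O`: 47 nM
Compound 2 `CC1(c2ccc(F)cc2)NC(=O)N(CC(O)CN2CCN(c3ccccc3C#N)CC2)C1=O`: 14 nM

Among the compounds with values here, in an assay on HEK293 cells for displacement of a labelled ligand from 5-hydroxytryptamine receptor 7 (Homo sapiens) (on this read-out higher numbers stand for weaker inhibition and lower numbers for stronger inhibition), compound 2 holds the lowest number of the two, with compound 1 the only neighbour, and that gap is a 3.4-fold lower number from compound 1 to compound 2 (0.53 log units; beyond the scatter), a modest change from cyano in place of chloro on an aromatic carbon. Compound 3 `CC1(c2ccc(F)cc2)NC(=O)N(CC(O)CN2CCN(c3ccc(F)cc3)CC2)C1=O` carries 4-fluorophenyl in place of 2-cyanophenyl on an amine nitrogen in a ring. Within the data shown here, no measured step exchanges both the group and its position in this way, so only the general size of the one known step offers guidance. Compound 3 is therefore expected to give 40 nM, within 12 nM to 130 nM, meaning an expected step of a 2.9-fold higher number from compound 2 to compound 3 (0.46 log units; beyond the scatter) toward a weaker result.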

Compound 3, inhibition constant: 837 nM
The estimate for compound 3 lay 21-fold (1.32 log units) below the measured number, outside the stated range (above it).
By their numbers in this assay, from the lowest: compound 2; then compound 1; then compound 3.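

Exchanging the whole aryl group on the amine nitrogen in a ring moves the number much further in this assay than the swap of chloro for cyano did: 4-fluorophenyl gives a 60-fold higher number from compound 2 to compound 3 (1.78 log units; beyond the scatter) and an 18-fold higher number from compound 1 to compound 3 (1.25 log units; beyond the scatter). Both steps are large and run toward weaker inhibition, so among these compounds, either 2-substituted phenyl group reads far stronger than 4-fluorophenyl. No evidence on why this happens is available. The compounds shown cannot separate the effect of the fluorine from that of where it sits on the ring. From the compounds shown here alone, how a plain phenyl or a methoxyphenyl would read at this position also remains open.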